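This account rests on a few compounds, and the source may have more. Where it says the series, first, only, none or still open, it means among the compounds named here.

Compound 1 `CCNC(=O)[C@H]1O[C@@H](n2cnc3c(NNC(=O)c4ccccc4)ncnc32)[C@H](O)[C@@H]1O` carries a benzamidoamino group on the shared core, with the sugar-like part bearing an ethylamide. In a functional assay on CHO cells for activation of adenosine receptor A2b (Homo sapiens), read by cAMP accumulation (a higher number here means that more compound is needed for the effect, a lower number that less compound is needed), compound 1 gives > 5000 nM, and this is a limit of the assay rather than a number, so compound 1 stands only at that limit on the numbers shown. Compound 2 `CCNC(=O)[C@H]1O[C@@H](n2cnc3c(NNC(=O)c4ccc(Cl)cc4)ncnc32)[C@H](O)[C@@H]1O` has chloro in place of hydrogen on an aromatic carbon of the benzamidoamino group; in this assay compound 2 gives > 5000 nM, which is likewise a limit. Compound 3 `CCNC(=O)[C@H]1O[C@@H](n2cnc3c(NNC(=O)c4cccnc4)ncnc32)[C@H](O)[C@@H]1O` has pyridin-3-yl in place of phenyl on a carbonyl carbon; in this assay compound 3 gives > 5000 nM, also a limit. The steps between them, a step that the two limits leave unreadable from compound 1 to compound 2, a step that the two limits leave unreadable from compound 1 to compound 3 and a step that the two limits leave unreadable from compound 2 to compound 3, cannot be read in size, because of the limit of > 5000 nM in this assay, at which 3 of the 3 values shown sit.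

Compound 4 `CCNC(=O)[C@H]1O[C@@H](n2cnc3c(NNC(=O)c4ccccc4)nc(Cl)nc32)[C@H](O)[C@@H]1O` differs from compound 1 by chloro in place of hydrogen on an aromatic carbon. Among the compounds with values here, none of the measured steps touches that place, and all three measured values sit at the limit, so no step in this assay can be read from them. The expectation is therefore that compound 4 stays near the limit, with an estimated step that the limit leaves unreadable from compound 1 to compound 4. Compound 4 is estimated at 8000 nM, within a range from 2000 nM to 40000 nM.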

Compound 4, half-maximal effective concentration: > 5000 nM
Compound 4: only a limit was reported; the forecaster's own chance of this, stated with the estimate: 80%; the middle value is on the limit's open side.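

In this assay compound 4 gives > 5000 nM, which is a limit and not a number. No size can be read for the change from compound 1 to compound 4, because both compounds stand at the same limit: the limit of > 5000 nM in this assay, at which 4 of the 4 values shown sit.

The compounds shown leave open whether the added chloro, or any other change seen here, alters how much compound is needed for the effect.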